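A few compounds are considered here, and "the series" means these few. Any claim that something is new, unique, unknown or untested is made for them only; others in the source may bear on it.

Compound 1 `CCC1(CCCCN2CCN(c3ccc(Cl)c(Cl)c3)CC2)C(=O)Nc2ccccc21` and compound 2 `CCC1(CCCCN2CCN(c3ccc(F)c(Cl)c3)CC2)C(=O)Nc2ccccc21` share one core and differ in a single place. In an assay on CHO cells for displacement of a labelled ligand from 5-hydroxytryptamine receptor 7 (Homo sapiens) (a lower number here means a stronger inhibitor, a higher number a weaker inhibitor), compound 1 gives 0.63 nM and compound 2 gives 0.6 nM, so a 1.1-fold lower number from compound 1 to compound 2 (0.02 log units; within the scatter), the change being (fluoro in place of chloro on an aromatic carbon). Compound 3 `CCC1(CCCCN2CC=C(c3ccc(Cl)cc3)CC2)C(=O)Nc2ccccc21` is built on another core; the difference between the two cores is not broken down here. In this assay compound 3 gives 1.02 nM, which lies within the scatter of both other values. Compound 4 `CCC1(CCCCN2CC=C(c3ccc(F)cc3)CC2)C(=O)Nc2ccccc21` has not yet been measured in this assay; it differs from compound 3 by fluoro in place of chloro on an aromatic carbon. Within the data shown here, this is the same kind of change as the one from compound 1 to compound 2, though the surroundings differ: in compound 1 the chloro that leaves sits ortho to a chloro group and para to a large group, whereas in compound 3 it sits only para to a large group. Because the earlier change gave a 1.1-fold lower number from compound 1 to compound 2 (0.02 log units; within the scatter), a step of similar size is expected here, a 1.0-fold lower number from compound 3 to compound 4 (0.01 log units; within the scatter). Compound 4 is therefore estimated at 1 nM, with a likely range from 0.5 nM to 2.2 nM.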

Compound 4, inhibition constant: 1.19 nM
The estimate for compound 4 lay 1.2-fold (0.08 log units) below the measured number; measured number inside the range.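

In this assay, going from 4-chlorophenyl to 4-fluorophenyl gives a 1.2-fold higher number from compound 3 to compound 4 (0.07 log units; within the scatter), so on this core the swap of chloro for fluoro has no effect that can be told from the noise of the measurement. Set beside the earlier step, the change carries across the two cores without a detectable difference: the same change on two cores in this assay, a 1.1-fold lower number (0.02 log units; within the scatter) from compound 1 to compound 2 and a 1.2-fold higher number (0.07 log units; within the scatter) from compound 3 to compound 4, 1.2-fold (0.09 log units) apart, within the scatter of two such steps. Among these compounds, this shows only that the swap made no readable difference on either core in these two pairs; since neither step stands clear of the scatter, it does not show that a change with a larger effect would carry over in the same way, and two pairs establish no rule for the series.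

The compounds shown leave open whether other groups in that place, such as a methoxy group, a nitrile or a plain hydrogen, would stay in the same range on both cores, and whether a longer chain on the core would do so too. On these data alone, all the values come from a single assay, so how these compounds behave at any other receptor also remains open.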